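This account rests on a few compounds, and the source may have more. Where it says the series, first, only, none or still open, it means among the compounds named here.

Measured in a functional assay on COLO 205 cells (Homo sapiens) for cytotoxicity, read by MTT assay, with a stated time of 24 h; on this read-out lower numbers stand for stronger inhibition and higher numbers for weaker inhibition:

compound 1 `FC(F)(F)C(F)(F)C(F)(F)C(F)(F)C(F)(F)C(F)(F)CCn1cc(COc2ccccc2-c2nc3ccccc3s2)nn1` gives 14200 nM
compound 2 `Fc1ccc(-n2cc(COc3ccccc3-c3nc4ccccc4s3)nn2)cc1` gives 18900 nM
compound 3 `Brc1ccc(-c2cc(COc3ccccc3-c3nc4ccccc4s3)on2)cc1` gives 16400 nM

Compound 1 shows the lowest of the three numbers, yet compound 3 and compound 2 both lie within the usual scatter of it, so no real difference among the three is established; all three sit in the same weak range. Compound 4 `FC(F)(F)C(F)(F)C(F)(F)C(F)(F)C(F)(F)C(F)(F)C(F)(F)C(F)(F)CCn1cc(COc2ccccc2-c2nc3ccccc3s2)nn1` differs from compound 1 in one place: 1,1,2,2,2-pentafluoroethyl in place of fluoro on a saturated chain carbon bound to two fluorine atoms and a saturated chain carbon. The fluorinated chain is simply extended at its far end, while the shared core and everything else stay as in compound 1. Among the compounds with values here, no measured pair shows what such a chain extension does here, so the step from compound 1 to compound 4 is expected to stay within the scatter, in no clear direction: a 1.0-fold lower number from compound 1 to compound 4 (0.01 log units; within the scatter). Compound 4 is therefore expected to give about 14000 nM, with a likely range from 5000 nM to 40000 nM.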

Compound 4, half-maximal inhibitory concentration: 12200 nM
For compound 4 the middle estimate is 1.1-fold (0.06 log units) above the measured one; measured number inside the range.
By their numbers in this assay, from the lowest: compounds 4, 1, 3 and 2 (each within the scatter of the next).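

Extending the fluorinated chain at its far end, with 1,1,2,2,2-pentafluoroethyl in place of fluoro, gives the first measured step at this position: a 1.2-fold lower number from compound 1 to compound 4 (0.07 log units; within the scatter) in this assay. The longer fluorinated chain is therefore accepted here, but it brings no real change in the number. Nothing on hand explains this result. Still open, on these data alone, is whether any change at the far end of this chain can move the number beyond the scatter, such as a plain hydrocarbon chain or a terminal amine or carboxylic acid.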